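Amide aryl removal in the triazole thioacetamide series

The source may report more compounds than this note shows. Statements on the series, on what has been measured and on what is new or still open speak of the compounds shown alone.

Compound 3 `Cc1occc1-c1nnc(SCC(=O)Nc2cccc(Cl)c2)n1Cc1ccco1` gives 63.1 nM in a functional assay on CHO cells for antagonist activity at Orexin receptor type 2 (Homo sapiens), read by FLIPR and calcium flux (on this read-out higher numbers stand for weaker inhibition and lower numbers for stronger inhibition), the highest of the two numbers in hand; its nearest neighbour compound 2 `Cc1occc1-c1nnc(SCC(=O)Nc2ccc(F)c(Cl)c2)n1Cc1ccco1` gives 39.8 nM, and the step of a 1.6-fold higher number from compound 2 to compound 3 (0.20 log units; within the scatter) stays within the scatter. Compound 1 `Cc1cccc(NC(=O)CSc2nnc(-c3ccoc3C)n2Cc2ccco2)c1C` returns only a limit in this assay, > 15800 nM. Compound 4 `Cc1occc1-c1nnc(SCC(N)=O)n1Cc1ccco1` carries hydrogen in place of 3-chlorophenyl on an amide-type nitrogen. The measured steps that touch this amide nitrogen are both large, an at least 390-fold lower number from compound 1 to compound 2 (2.59 log units; beyond the scatter) and an at least 250-fold lower number from compound 1 to compound 3 (2.39 log units; beyond the scatter), so the group on that nitrogen moves the number strongly. Among the compounds with values here, no measured compound lacks the aryl group altogether, yet because of an at least 390-fold lower number from compound 1 to compound 2 (2.59 log units; beyond the scatter) and an at least 250-fold lower number from compound 1 to compound 3 (2.39 log units; beyond the scatter) a large rise in the number is expected for compound 4, a 320-fold higher number from compound 3 to compound 4 (2.50 log units; beyond the scatter). Compound 4 is therefore estimated at 20000 nM, with a range of 3000 nM to 100000 nM, and a limit-only result is likely.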

Compound 4, inhibition constant: > 15800 nM
Compound 4 ended at the assay's limit (the forecaster's own chance of this, stated with the estimate: 70%); the middle value does not contradict the limit.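

Replacing the aryl group on the amide-type nitrogen with hydrogen gives an at least 250-fold higher number from compound 3 to compound 4 (2.39 log units; beyond the scatter) and an at least 390-fold higher number from compound 2 to compound 4 (2.59 log units; beyond the scatter), so the aryl group itself, and not only its substitution, counts at this position. Among the four compounds, a readable number appears only with 3-chlorophenyl or 3-chloro-4-fluorophenyl on this nitrogen. The step between compound 1 and compound 4 cannot be read, as both results are limits: the limit of > 15800 nM in this assay, at which 2 of the 4 values shown sit.

From the compounds shown here alone, whether a methyl group, a longer chain or a benzyl group on this nitrogen would return a readable number stays open. So does the result for an unsubstituted phenyl group.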